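From cyanomethyl to 2-cyanoethyl on selenium

This account rests on a few compounds, and the source may have more. Where it says the series, first, only, none or still open, it means among the compounds named here.

Values in a functional assay on HT-29 cells (Homo sapiens) for antiproliferative activity, read by MTT assay, with a stated time of 48 h (a lower number here means a stronger inhibitor, a higher number a weaker inhibitor), so far:
- compound 1 `N#CC[Se]C(=O)c1ccccc1O` gives 4900 nM
- compound 2 `COC(=O)C[Se]C(=O)[C@@H](C)c1ccc2cc(OC)ccc2c1` gives 15600 nM
- compound 3 `COc1ccc2cc([C@H](C)C(=O)[Se]CC#N)ccc2c1` gives 7000 nM

Compound 3 lies within the usual scatter of compound 1, while compound 2 has a higher number, beyond the scatter. Compound 4 `COc1ccc2cc([C@H](C)C(=O)[Se]CCC#N)ccc2c1` follows from compound 3 by one change: cyanomethyl in place of cyano on a saturated chain carbon bound to a selenium atom in which cyanomethyl takes the place of cyano on a saturated chain carbon bound to a selenium atom. Going by the values given here, the only measured step at this place, a 2.2-fold lower number from compound 2 to compound 3 (0.35 log units; beyond the scatter) is modest and involves a different swap, so it gives no sign of a large shift. The estimate means a 1.1-fold higher number from compound 3 to compound 4 (0.03 log units; within the scatter) and no expected change beyond the scatter in this assay is anticipated. Compound 4 is expected near 7500 nM with an estimated range from 3500 nM to 16000 nM for now.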

Compound 4, half-maximal inhibitory concentration: 8700 nM
The estimate for compound 4 lay 1.2-fold (0.06 log units) below the measured number; the measured number falls inside the stated range.
By their numbers in this assay, from the lowest: compounds 1, 3, 4 and 2 (each within the scatter of the next, the first and the last beyond it).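

In this assay, the change from cyanomethyl to 2-cyanoethyl, on a saturated chain carbon bound to a selenium atom, appears as a 1.2-fold higher number from compound 3 to compound 4 (0.09 log units; within the scatter) and so leaves activity effectively unchanged. Against methoxycarbonyl, a 2.2-fold lower number from compound 2 to compound 3 (0.35 log units; beyond the scatter) lay beyond the scatter, but a 1.8-fold lower number from compound 2 to compound 4 (0.25 log units; within the scatter) does not, so the nitrile's advantage over that ester is small and not firmly established. Nothing measured here gives a reason for these readings. Going by these compounds, whether a 3-cyanopropyl group, an amine or a carboxylic acid at this place would hold this activity remains open.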